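Swapping the Trifluoromethoxy for Methylsulfonyl on the Aniline Ring

The source may hold more compounds than are shown below. What is called first, only, known or untested is meant among the compounds shown, and "the series" means these compounds.

Measured so far:
- compound 1 `CN(C)CC[C@H](CSc1ccccc1)Nc1ccc(S(=O)(=O)NC(=O)c2ccc(N3CCN(Cc4ccccc4-c4ccc(Cl)cc4)CC3)cc2)cc1OC(F)(F)F` gives 5080 nM in a functional assay on NCI-H146 cells (Homo sapiens) for cytotoxicity, with a stated time of 48 h, in the presence of a further agent that is not named here; a lower number here means that less compound is needed, a higher number that more compound is needed for the effect
- compound 2 `CN(C)CC[C@H](CSc1ccccc1)Nc1ccc(S(=O)(=O)NC(=O)c2ccc(N3CCN(Cc4ccccc4-c4ccc(Cl)cc4)CC3)cc2)cc1C(F)(F)F` gives 2460 nM in this assay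
- compound 3 `CN(C)CC[C@H](CSc1ccccc1)Nc1ccc(S(=O)(=O)NC(=O)c2ccc(N3CCN(CC4=C(c5ccc(Cl)cc5)CCC4)CC3)cc2)cc1[N+](=O)[O-]` gives 691 nM in this assay

Compound 1 needs the most compound of the three. Its nearest neighbour in the numbers is compound 2, with a 2.1-fold lower number from compound 1 to compound 2 (0.31 log units; beyond the scatter); this pair differs only in that one group. Among the compounds with values here, compound 3 lies furthest away, but it differs from compound 1 in two places, so its lower value shows only that a substantial change in this region, combined with a changed tail, can go along with a far lower number.

Compound 4 `CN(C)CC[C@H](CSc1ccccc1)Nc1ccc(S(=O)(=O)NC(=O)c2ccc(N3CCN(Cc4ccccc4-c4ccc(Cl)cc4)CC3)cc2)cc1S(C)(=O)=O` is not yet measured. It differs from compound 1 by methylsulfonyl in place of trifluoromethoxy on an aromatic carbon, on the aromatic carbon that is ortho to a large group and meta to a large group.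

Within the data shown here, the only step that bears directly on this change is the one from compound 1 to compound 2, a modest lowering of the number when one small group replaces another on this carbon. Nothing measured pairs methylsulfonyl with anything else. A modest lowering is therefore expected, with wide uncertainty.

Compound 4 is estimated at 2500 nM, within 800 nM to 8000 nM, which is expected to be a 2.0-fold lower number from compound 1 to compound 4 (0.31 log units; beyond the scatter).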

Compound 4, half-maximal effective concentration: 34900 nM
Compound 4: middle estimate off by 14-fold (1.14 log units), on the low side; measured number above the stated range.
By their numbers in this assay, from the lowest: compound 3; then compound 2; then compound 1; then compound 4.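

In this assay, this aromatic carbon proves far more sensitive to the choice of group than the first pair suggested: beside the earlier 2.1-fold lower number from compound 1 to compound 2 (0.31 log units; beyond the scatter), methylsulfonyl gives a 6.9-fold higher number from compound 1 to compound 4 (0.84 log units; beyond the scatter) and a 14-fold higher number from compound 2 to compound 4 (1.15 log units; beyond the scatter). The same carbon can therefore move the number in either direction, and the step between the two fluorinated groups gave no warning of how large the change could be. Heavy-atom count does not follow this rise, as methylsulfonyl has fewer heavy atoms than the trifluoromethoxy it replaces, and no measurement shown here explains the higher number.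

Within the data shown here, with only three groups compared on the same remainder of the molecule, it remains open whether the rise is specific to methylsulfonyl or would also appear with a nitrile, an amine or a primary sulfonamide on this carbon. On these data alone, it is also open how nitro would behave on the tail shared by compound 1, compound 2 and compound 4, since compound 3 carries it on a different tail.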